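The compounds below may be only part of what the source reports. "The series", "measured", "known", "first", "only" and "open" are said of these compounds alone.

Within the data shown here, compound 1 `Cc1ccc(-c2noc(CN3N=N[C@@H]4C(=O)N(c5ccccc5)C(=O)[C@@H]43)n2)cc1` is the only member of this small series with a numerical reading: in an ADME assay on L6 cells (Rattus norvegicus) for cytotoxicity, read by resazurin assay, with a stated time of 72 h (on this read-out higher numbers stand for weaker inhibition and lower numbers for stronger inhibition), compound 1 gives 15.2 ug/mL. Compound 2 `O=C1[C@H]2N=NN(Cc3nc(-c4ccc([N+](=O)[O-])cc4)no3)[C@H]2C(=O)N1c1ccccc1` reaches only the limit of the assay, with > 100 ug/mL, and compound 3 `CSc1ccc(-c2noc(CN3N=N[C@@H]4C(=O)N(c5ccccc5)C(=O)[C@@H]43)n2)cc1` likewise reaches only that limit, with > 100 ug/mL. The steps from compound 1 are therefore both bounded from below: an at least 6.5-fold higher number from compound 1 to compound 2 (0.81 log units; beyond the scatter) and an at least 6.5-fold higher number from compound 1 to compound 3 (0.81 log units; beyond the scatter), whereas a step that the two limits leave unreadable from compound 2 to compound 3. Compound 3 thus stands at the upper edge of what this assay reports, sharing that position with one other compound (the limit of > 100 ug/mL in this assay, at which 2 of the 3 values shown sit).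

Compound 4 `CN(C)c1ccc(-c2noc(CN3N=N[C@@H]4C(=O)N(c5ccccc5)C(=O)[C@@H]43)n2)cc1` differs from compound 3 in a single place: dimethylamino in place of methylsulfanyl on an aromatic carbon. Among the measured compounds shown here, no measured step bears directly on a dimethylamino group, and the one step ending at compound 3 carries only a lower bound, so the direction of the change cannot be read from the data. Given that compound 3 already sits at the limit, the weight of the shown values is on compound 4 remaining near it. Compound 4 is therefore estimated at 70 ug/mL, within a range from 20 ug/mL to 200 ug/mL, which would mean an expected step of an at least 1.4-fold lower number from compound 3 to compound 4 (0.15 log units; that floor lies within the scatter).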

Compound 4, half-maximal inhibitory concentration: > 100 ug/mL
Compound 4 ended at the assay's limit; the forecaster's own chance of this, stated with the estimate: 50%; middle value at least 1.4-fold (0.15 log units) from the limit.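

In this assay compound 4 gives > 100 ug/mL, which is a limit of the assay and not a number. The change from methyl to dimethylamino gives an at least 6.5-fold higher number from compound 1 to compound 4 (0.81 log units; beyond the scatter), so three different groups have now replaced methyl at this place on the aromatic ring with a step beyond the scatter, and compound 1 remains the only compound shown with a numerical reading. The steps among compound 2, compound 3 and compound 4 cannot be read, so the methylsulfanyl-to-dimethylamino change adds no ranking of these groups, and the new result only places one more compound at the same edge of the read-out: the limit of > 100 ug/mL in this assay, at which 3 of the 4 values shown sit.

On these data alone, what remains open is whether the numerical reading belongs to methyl alone, or whether an ethyl group, a methoxy group or a fluorine at this place would also give one rather than joining the limit. As far as these compounds go, it is also open whether a primary amine or a carboxylic acid there would stay at the limit, as the dimethylamino group does in compound 4.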